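Replacing 2-chlorophenyl with 4-cyanophenyl in compound 3

The source may hold more compounds than are shown below. What is called first, only, known or untested is meant among the compounds shown, and "the series" means these compounds.

In a physicochemical assay for lipophilicity (a lower number here means a more polar compound, a higher number a more lipophilic compound), compound 2 `C[C@H]1CC[C@@H]2[C@@H](OC(=O)[C@]23CC(c2ccccc2Cl)=NO3)[C@]2(C)C(=O)C=C[C@@]12O` stands highest of the two measured compounds at 2.09, while compound 1 `C[C@H]1CC[C@@H]2[C@@H](OC(=O)[C@]23CC(c2ccc([N+](=O)[O-])cc2)=NO3)[C@]2(C)C(=O)C=C[C@@]12O` gives 1.37. Compound 3 `C[C@H]1CC[C@@H]2[C@@H](OC(=O)[C@]23CC(c2ccc(C#N)cc2)=NO3)[C@]2(C)C(=O)C=C[C@@]12O` differs from compound 2 in one place: 4-cyanophenyl in place of 2-chlorophenyl on a carbon with a double bond to nitrogen. Within the data shown here, one measured step bears on this change: with 2-chlorophenyl in place of 4-nitrophenyl, the number moved as follows: a number 0.72 log units higher from compound 1 to compound 2 (beyond the scatter). Compound 3 also lacks the 2-chlorophenyl group, so a step of similar size in the opposite direction is expected in this assay. The estimated step is a number 0.74 log units lower from compound 2 to compound 3 (beyond the scatter). The estimated value for compound 3 is 1.35, within a range of 1 to 1.7.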

Compound 3, partition coefficient: 1.17
For compound 3 the middle estimate is 0.18 log units above the measured one; low and high end bracket the measured number.
By their numbers in this assay, from the lowest: compounds 3 and 1 (each within the scatter of the next); then compound 2.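

In this assay, 4-cyanophenyl and 4-nitrophenyl cannot be told apart at this position: cyano in place of nitro gives a number 0.20 log units lower from compound 1 to compound 3 (within the scatter). By contrast, 4-cyanophenyl in place of 2-chlorophenyl gives a number 0.92 log units lower from compound 2 to compound 3 (beyond the scatter), so compound 2 stands apart from both compound 1 and compound 3. No measurement here explains this gap. Still open, going by these compounds, is whether the gap follows the chlorine itself or its place on the ring, which a 4-chlorophenyl group could separate. On these data alone, how an amine or a carboxylic acid on this phenyl ring would read also remains open.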